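The source may report more compounds than this note shows. Statements on the series, on what has been measured and on what is new or still open speak of the compounds shown alone.

Measured compounds:
- compound 1, `CCCCCCNc1nc(-c2ccccc2)nc2c1nnn2Cc1ccccc1`: 13.2 nM
- compound 2, `c1ccc(Cn2nnc3c(NC4CCC4)nc(-c4ccccc4)nc32)cc1`: 5 nM

Going by the values given here, compound 2 stands at the lower of the two numbers in an assay on Cerebral cortex for displacement of a labelled ligand from adenosine receptor A1 (Bos taurus); a lower number here means a stronger inhibitor, a higher number a weaker inhibitor; its nearest neighbour is compound 1, and the one step between them, a 2.6-fold lower number from compound 1 to compound 2 (0.42 log units; beyond the scatter), lies beyond the scatter. Compound 3, `c1ccc(Cn2nnc3c(NC4CCCC4)nc(-c4ccccc4)nc32)cc1`, has not yet been measured. It differs from compound 2 in one place: cyclopentyl in place of cyclobutyl on a nitrogen on an aromatic ring. Among the compounds with values here, only one measured step bears on this change, the step of a 2.6-fold lower number from compound 1 to compound 2 (0.42 log units; beyond the scatter), in which a hexyl chain on that nitrogen was replaced by a cyclobutyl ring and the number fell. That step speaks for small rings on this nitrogen being tolerated at least as well as an open chain, but it does not tell how a four-membered ring compares with a five-membered one. On that basis compound 3 is expected to give a number close to that of compound 2, with a modest lowering considered somewhat more likely than a rise, so that the estimated step is a 1.6-fold lower number from compound 2 to compound 3 (0.19 log units; within the scatter). The value of compound 3 in this assay is estimated at 3.2 nM, within the range 1.2 nM to 9 nM.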

Compound 3, inhibition constant: 11 nM
Compound 3: middle estimate off by 3.4-fold (0.54 log units), on the low side; measured number outside the range, above it.
By their numbers in this assay, from the lowest: compound 2; then compounds 3 and 1 (each within the scatter of the next).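

With a 2.2-fold higher number from compound 2 to compound 3 (0.34 log units; beyond the scatter) in this assay the size of the ring on this nitrogen proves to matter: one more ring carbon, cyclopentyl for cyclobutyl, is enough to move the number beyond the scatter, something the earlier step from an open chain to a ring could not show. With a 1.2-fold lower number from compound 1 to compound 3 (0.08 log units; within the scatter) the cyclopentyl and hexyl compounds cannot be told apart, so having a ring on this nitrogen does not by itself give a lower number than the open chain, and among the compounds shown only cyclobutyl stands apart from the other two groups. No evidence at hand accounts for the difference between the four-membered and the five-membered ring.

It remains open how cyclopropyl or cyclohexyl on this nitrogen would compare, so the compounds shown do not yet give a trend across ring sizes. Also open, from the compounds shown here alone, is whether a shorter chain such as butyl would stand with hexyl or with cyclobutyl, and whether a hydroxyl group on the cyclopentyl ring would shift the number.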